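Chain Extension of a Benzyl Ester in a Dihydropyridine Series

This account rests on a few compounds, and the source may have more. Where it says the series, first, only, none or still open, it means among the compounds named here.

Compound 1, `COCC1=C(C(=O)OC)C(c2cccc([N+](=O)[O-])c2)C(C(=O)OC)=C(C)N1`, gives 115 nM.
Compound 2, `CCOC(=O)C1=C(C)NC(C)=C(C(=O)OCCOC)C1c1cccc([N+](=O)[O-])c1`, gives 16 nM.
Compound 3, `COC(=O)C1=C(C)NC(C)=C(C(=O)OCc2ccccc2)C1c1cccc([N+](=O)[O-])c1`, gives 25 nM.

The three compounds were tested in a functional assay on HEK293 cells for antagonist activity at Voltage-dependent L-type calcium channel subunit alpha-1C (Oryctolagus cuniculus), read by FLIPR; on this read-out lower numbers stand for stronger inhibition and higher numbers for weaker inhibition. Compound 3 sits between the other two: its number lies within the scatter of compound 2, so the two cannot be told apart, while compound 1 stands clearly higher, beyond the scatter. Compound 4, `COC(=O)C1=C(C)NC(C)=C(C(=O)OCCOCc2ccccc2)C1c1cccc([N+](=O)[O-])c1`, has not yet been measured.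

Compound 4 differs from compound 3 at one point: (benzyloxy)methyl in place of phenyl on a saturated chain carbon bound to an oxygen next to a carbonyl group. Cut one bond further out, the same difference reads benzyl to 2-(benzyloxy)ethyl. Compound 2, whose ester chain also carries an ether oxygen, gives a number within the scatter of compound 3, which is the only hint available about how a chain of this kind is tolerated here.

Going by the values given here, no measured pair shows this exact change, so the expectation rests on the closeness of compound 2 and compound 3. The step of a 1.3-fold lower number from compound 3 to compound 4 (0.10 log units; within the scatter) is expected to be small, with no direction beyond the scatter. Compound 4 is therefore estimated at 20 nM, with a range from 7 nM to 60 nM.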

Compound 4, half-maximal inhibitory concentration: 9 nM
For compound 4 the middle estimate is 2.2-fold (0.35 log units) above the measured one, within the range that was stated.
By their numbers in this assay, from the lowest: compounds 4, 2 and 3 (each within the scatter of the next, the first and the last beyond it); then compound 1.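

In this assay, going by these compounds alone, the change from benzyl to 2-(benzyloxy)ethyl gives a 2.8-fold lower number from compound 3 to compound 4 (0.44 log units; beyond the scatter) and so provides the first step at this ester chain that can be read in one place, since no two earlier compounds differed at only one point. The step is modest but beyond the scatter, which shows that this position accepts the longer chain with a lower number rather than merely without loss. At the saturated chain carbon bound to an oxygen next to a carbonyl group, phenyl with 6 heavy atoms and 0 hydrogen-bond acceptors gives way to (benzyloxy)methyl with 9 heavy atoms and 1 hydrogen-bond acceptor, while the aromatic ring of carbon remains; nothing available explains why the number falls with this change.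

The compounds shown leave open whether the lower number goes with the ether oxygen or with the added length, a question that a 3-phenylpropyl ester, with carbon alone in its chain, would help to settle. Also open, on these data alone, is how this position would respond to an amine in place of the ether oxygen, or to a carboxylic acid at the end of the chain.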